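The source may hold more compounds than are shown below. What is called first, only, known or untested is meant among the compounds shown, and "the series" means these compounds.

Measured in a functional assay on A549 cells (Homo sapiens) for cytotoxicity, read by sulforhodamine B assay, with a stated time of 72 h; on this read-out lower numbers stand for stronger inhibition and higher numbers for weaker inhibition:
compound 1 `CCS(=O)(=O)Nc1cc(-c2ccc3ncnc(Nc4cccc(F)c4)c3c2)cnc1OC` gives 9940 nM;
compound 2 `CCS(=O)(=O)Nc1cc(-c2ccc3ncnc(Nc4ccc(OC(F)(F)F)cc4)c3c2)cnc1OC` gives 25400 nM;
compound 3 `CCS(=O)(=O)Nc1cc(-c2ccc3ncnc(Nc4ccc(OC)cc4)c3c2)cnc1OC` gives 3580 nM.

Of these three numbers, compound 3 stands lowest, and both steps towards it are beyond the scatter: a 2.8-fold lower number from compound 1 to compound 3 (0.44 log units; beyond the scatter) and a 7.1-fold lower number from compound 2 to compound 3 (0.85 log units; beyond the scatter). Compound 4 `CCS(=O)(=O)Nc1cc(-c2ccc3ncnc(Nc4cccc(C(=O)OC)c4)c3c2)cnc1OC` is not yet measured. It differs from compound 3 in one place: 3-(methoxycarbonyl)phenyl in place of 4-methoxyphenyl on a nitrogen on an aromatic ring.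

The measured steps that bear on this change are the ones in which the same phenyl group was exchanged: a 2.6-fold higher number from compound 1 to compound 2 (0.41 log units; beyond the scatter), a 2.8-fold lower number from compound 1 to compound 3 (0.44 log units; beyond the scatter) and a 7.1-fold lower number from compound 2 to compound 3 (0.85 log units; beyond the scatter). Going by the values given here, all three are modest, and none involves a methoxycarbonyl group, so there is no direct precedent for compound 4. Since compound 3 already holds the lowest number and the other two phenyl variants gave higher numbers, compound 4 is expected to sit somewhat higher than compound 3, by a modest step: a 2.0-fold higher number from compound 3 to compound 4 (0.29 log units; within the scatter). The estimate for compound 4 in this assay is 7000 nM, with a range from 2500 nM to 20000 nM.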

Compound 4, half-maximal inhibitory concentration: 1100 nM
The estimate for compound 4 lay 6.4-fold (0.80 log units) above the measured number, and the stated range ends above it.
By their numbers in this assay, from the lowest: compound 4; then compound 3; then compound 1; then compound 2.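

In this assay, 3-(methoxycarbonyl)phenyl on this nitrogen goes below every phenyl group seen before, with a 3.3-fold lower number from compound 3 to compound 4 (0.51 log units; beyond the scatter) and a 9.0-fold lower number from compound 1 to compound 4 (0.96 log units; beyond the scatter) and, as the largest step of the set, a 23-fold lower number from compound 2 to compound 4 (1.36 log units; beyond the scatter) in this series. The step from compound 1 is the plainest comparison, since only fluoro gives way to methoxycarbonyl on an aromatic carbon, so this place on the ring can take a larger group than fluoro without the number rising. Nothing measured here explains why the number falls.

The compounds shown cannot separate the effect of the methoxycarbonyl group itself from that of where it sits, which 4-(methoxycarbonyl)phenyl would address. From the compounds shown here alone, it also remains open whether a carboxylic acid or a primary amide in its place would give a similar number.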